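The source may report more compounds than this note shows. Statements on the series, on what has been measured and on what is new or still open speak of the compounds shown alone.

Of the compounds shown here, two have been measured so far. Compound 1 `Cc1cccc(Cc2nc3cc(O[C@H]4CC[C@@H](C(=O)O)CC4)ccc3o2)c1` gives, in an assay on isolated protein for inhibition of Long-chain-fatty-acid--CoA ligase 1 (Homo sapiens), read by mass spectrometry, with a stated time of 90 min, in the presence of a further agent that is not named here (a higher number here means a weaker inhibitor, a lower number a stronger inhibitor), a reading of 39 nM. Compound 2 `Cc1ccccc1Cc1nc2cc(O[C@H]3CC[C@@H](C(=O)O)CC3)ccc2n1C` gives, in this assay, a reading of 7800 nM, the higher of the two numbers and so the weaker inhibitor, a gap well beyond the scatter. Compound 1 and compound 2 differ from each other in more than one place, so the gap between them cannot be tied to any single change.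

Compound 3 `Cn1c(Cc2cccnc2)nc2cc(O[C@H]3CC[C@@H](C(=O)O)CC3)ccc21` has not yet been measured. It arises from compound 2 by one change: pyridin-3-yl in place of 2-methylphenyl on a saturated chain carbon bound to an aromatic carbon. The measured pair says nothing direct about this change, since compound 1 carries a different core and a different arrangement of its methyl group rather than a ring nitrogen. Within the data shown here, with no comparable step to lean on, the expected step from compound 2 to compound 3 in this assay is a 1.6-fold lower number from compound 2 to compound 3 (0.19 log units; within the scatter), a small movement toward a lower number that may well stay within the scatter. Compound 3 is therefore expected to give 5000 nM in this assay, with a range from 1500 nM to 20000 nM.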

Compound 3, half-maximal inhibitory concentration: 141000 nM
The estimate for compound 3 lay 28-fold (1.45 log units) below the measured number; the whole stated range lies below it.
By their numbers in this assay, from the lowest: compound 1; then compound 2; then compound 3.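

Among these compounds, compound 3 gives the first comparison in this set that differs in only one place: on a saturated chain carbon bound to an aromatic carbon, pyridin-3-yl in place of 2-methylphenyl gives an 18-fold higher number from compound 2 to compound 3 (1.26 log units; beyond the scatter) in this assay. This position is therefore far from indifferent to the group it carries, even though both groups are six-membered aromatic rings and differ by only one heavy atom in total. The change removes a methyl group and puts a nitrogen into the ring in a single step, and no measurement shown here explains why the number rises so far.

From the compounds shown here alone, it remains open whether the rise follows the lost methyl group, the added ring nitrogen or both, and a plain phenyl group, which has neither, would help separate the two. Also open, going by these compounds, is whether the ring nitrogen matters in other ring positions, as in pyridin-4-yl, and whether the same change would have a similar effect on the core of compound 1, which differs from compound 3 in more than one place.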